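The source may hold more compounds than are shown below. What is called first, only, known or untested is meant among the compounds shown, and "the series" means these compounds.

Measured compounds:
- compound 1 `Cn1c(N2CCCC2)c(C#N)c2c(N)ncnc21`: 1480 nM
- compound 2 `Cc1nn(C2COC2)cc1Nc1nc(N)c2c(C#N)c(N3CCC[C@H]3C)n(C)c2n1`: 38 nM
- compound 3 `C[C@H]1CCCN1c1c(C#N)c2c(N)ncnc2n1C`: 5660 nM

All three were tested in an assay on isolated protein for inhibition of Leucine-rich repeat serine/threonine-protein kinase 2 (Homo sapiens), read by TR-FRET and LanthaScreen, with stated times of 50 min and 30 min, in the presence of a further agent that is not named here; a higher number here means a weaker inhibitor, a lower number a stronger inhibitor. Compound 2 gives the lowest number of the three, and the numbers of compound 1 and compound 3 both lie well above it, beyond the scatter in each case. Among the measured compounds shown here, the only step between two measured compounds that differ in one place is a 3.8-fold higher number from compound 1 to compound 3 (0.58 log units; beyond the scatter), a change on the saturated ring that compound 2 and compound 4 both carry in its methylated form.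

Compound 4 `Cc1n[nH]cc1Nc1nc(N)c2c(C#N)c(N3CCC[C@H]3C)n(C)c2n1` differs from compound 2 in one place: hydrogen in place of oxetan-3-yl on an aromatic nitrogen. For the measured compounds named here, no measured step bears directly on this change, since the one measured step concerns a saturated ring carbon rather than the aromatic nitrogen of the five-membered ring. With nothing to anchor the direction, and the rest of the structure of compound 2 kept intact, the reasonable expectation is a number close to that of compound 2, with the outcome possibly remaining within the scatter. Compound 4 is therefore expected to give about 60 nM in this assay, within a range from 15 nM to 250 nM. This estimate amounts to an expected step of a 1.6-fold higher number from compound 2 to compound 4 (0.20 log units; within the scatter), which may not exceed the scatter.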

Compound 4, half-maximal inhibitory concentration: 42 nM
The estimate for compound 4 lay 1.4-fold (0.15 log units) above the measured number; the range from low to high includes it.
By their numbers in this assay, from the lowest: compounds 2 and 4 (each within the scatter of the next); then compound 1; then compound 3.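

In this assay, the exchange of oxetan-3-yl for hydrogen on the aromatic nitrogen of the five-membered ring gives a 1.1-fold higher number from compound 2 to compound 4 (0.04 log units; within the scatter), so the two compounds cannot be told apart and this nitrogen keeps its reading with or without the four heavy atoms of the oxetan-3-yl group. Among the compounds shown here, the earlier compounds could not show this: neither compound 1 nor compound 3 carries the 3-methyl-1H-pyrazol-4-yl group, and the only earlier step, a 3.8-fold higher number from compound 1 to compound 3 (0.58 log units; beyond the scatter), concerns a methyl on a saturated ring carbon, whereas compound 4 now shows that with plain hydrogen on this nitrogen the number stands at 42 nM in this assay without the hydrogen-bond acceptor of the oxetane ring. Nothing measured here accounts for how closely the two numbers agree.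

The compounds shown leave open whether this insensitivity is particular to hydrogen and oxetan-3-yl, or whether a methyl, a longer alkyl chain, an amine or a carboxylic acid on the same nitrogen would also give a number in this range. They also leave open whether the same exchange would read alike with the unmethylated saturated ring of compound 1.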